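Amide substituent swap on a shared core: compound 3

The source may report more compounds than this note shows. Statements on the series, on what has been measured and on what is new or still open speak of the compounds shown alone.

Measured so far:
compound 1 `CCCCNC(=O)c1c(O)c2cccnc2n(-c2ccccc2)c1=O`: 20.4%
compound 2 `O=C(NCc1ccccc1)c1c(O)c2cccnc2n(-c2ccccc2)c1=O`: 11.3%

In a functional assay on the whole organism for inhibition, with Rattus norvegicus as the target, read by cytopathic effect and paw edema, at a dose of 100 mg/kg by the oral route (on this read-out higher numbers stand for more inhibition at the one dose given (going by the name of the read-out) and lower numbers for less inhibition), compound 2 gives 11.3%, the lowest of the two numbers; compound 1 gives 20.4%, and the two lie within the scatter of each other. Compound 3 `Cc1cccc(NC(=O)c2c(O)c3cccnc3n(-c3ccccc3)c2=O)c1` differs from compound 2 only at the amide-type nitrogen: 3-methylphenyl in place of benzyl on an amide-type nitrogen. Among the measured compounds shown here, the one measured step touching that position, a number 9.1 percentage points lower from compound 1 to compound 2 (within the scatter), stayed within the scatter, so no step beyond the scatter is expected here either: the expected change is a number 3.7 percentage points higher from compound 2 to compound 3 (within the scatter). Compound 3 is therefore estimated at 15%, with a range from 0% to 35%.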

Compound 3, a percentage reported as inhibition, in the whole organism at one dose (the size of the read-out at that dose, not a potency): 4.5%
Compound 3: middle estimate off by 10.5 percentage points, on the high side; the measured number falls inside the stated range.
By their numbers in this assay, from the lowest: compounds 3, 2 and 1 (each within the scatter of the next, the first and the last beyond it).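

Among the compounds shown here, the step of a number 15.9 percentage points lower from compound 1 to compound 3 (beyond the scatter) in this assay is the first at this amide-type nitrogen to pass the scatter, with 3-methylphenyl in place of butyl. By contrast, the step of a number 6.8 percentage points lower from compound 2 to compound 3 (within the scatter) does not separate 3-methylphenyl from benzyl, two groups with the same count of heavy atoms. Nothing available explains the difference between butyl and 3-methylphenyl.

From the compounds shown here alone, whether a longer chain such as hexyl would hold or raise the number remains open. So does the effect of a chain ending in an amine or a carboxylic acid on this nitrogen.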